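Chalcone series: bromine moved on the aryl ring

The compounds below may be only part of what the source reports. "The series", "measured", "known", "first", "only" and "open" are said of these compounds alone.

Measured so far:
- compound 1 `O=C(COc1ccc(C(=O)/C=C/c2ccccc2Cl)cc1)N[C@H]1CCOC1=O`, 4610 nM in a functional assay on PC-3 cells (Homo sapiens) for antiproliferative activity, read by MTT assay, with a stated time of 72 h; a lower number here means a stronger inhibitor, a higher number a weaker inhibitor
- compound 2 `CC(C)(C)c1ccc(/C=C/C(=O)c2ccc(OCC(=O)N[C@H]3CCOC3=O)cc2)cc1`, 10600 nM in this assay
- compound 3 `O=C(COc1ccc(C(=O)/C=C/c2cccc(Br)c2)cc1)N[C@H]1CCOC1=O`, 7890 nM in this assay

Compound 3 sits close to both other numbers; its steps to them are within the scatter: a 1.3-fold lower number from compound 2 to compound 3 (0.13 log units; within the scatter) and a 1.7-fold higher number from compound 1 to compound 3 (0.23 log units; within the scatter). Compound 4 `O=C(COc1ccc(C(=O)/C=C/c2ccccc2Br)cc1)N[C@H]1CCOC1=O` differs from compound 3 by 2-bromophenyl in place of 3-bromophenyl on a double-bonded chain carbon bound to a double-bonded chain carbon.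

Going by the values given here, the one measured step that bears on this change is the move from compound 1 to compound 3, where a halogen on the phenyl ring changes position and identity: a 1.7-fold higher number from compound 1 to compound 3 (0.23 log units; within the scatter), within the scatter. The step from compound 1 to compound 2, a 2.3-fold higher number from compound 1 to compound 2 (0.36 log units; beyond the scatter), is modest and concerns a different group. Nothing here separates the position of the halogen from its identity, so the most that can be expected for compound 4 is a return toward the number of compound 1, without a step beyond the scatter in this assay.

The expected step is a 1.4-fold lower number from compound 3 to compound 4 (0.16 log units; within the scatter), and it is an estimate only. Compound 4 is expected near 5500 nM, in the range 2500 nM to 12000 nM.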

Compound 4, half-maximal inhibitory concentration: 3260 nM
Compound 4: the middle estimate sits 1.7-fold (0.23 log units) above what was measured; the measured number falls inside the stated range.
By their numbers in this assay, from the lowest: compounds 4, 1, 3 and 2 (each within the scatter of the next, the first and the last beyond it).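

With the halogen held as bromine, 2-bromophenyl in place of 3-bromophenyl gives a 2.4-fold lower number from compound 3 to compound 4 (0.38 log units; beyond the scatter) in this assay and so goes beyond the scatter, which shows that the halogen's place on this ring matters by itself, something the mixed change from compound 1 to compound 3 could not separate. The change of halogen alone, bromo in place of chloro on an aromatic carbon, gives a 1.4-fold lower number from compound 1 to compound 4 (0.15 log units; within the scatter) and stays small, while 2-bromophenyl in place of 4-(tert-butyl)phenyl gives a 3.3-fold lower number from compound 2 to compound 4 (0.51 log units; beyond the scatter) as a modest step. The data shown offer no measured basis for explaining these steps.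

Open, as far as these compounds go, is how a 4-bromophenyl group would compare. Also open, from the compounds shown here alone, is whether a 2-fluorophenyl or 2-methoxyphenyl group would read like the 2-chlorophenyl and 2-bromophenyl groups.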